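The source may report more compounds than this note shows. Statements on the series, on what has been measured and on what is new or still open speak of the compounds shown alone.

Measured compounds:
`FC(F)(F)c1ccc2[nH]c(-c3ccccc3)nc2c1` compound 1, with 369000 nM
`O=[N+]([O-])c1ccccc1-c1nc2cc(C(F)(F)F)ccc2[nH]1` compound 2, with 3180 nM
`COc1cc(-c2nc3cc(C(F)(F)F)ccc3[nH]2)ccc1O` compound 3, with 34800 nM

In a functional assay on aorta (Rattus norvegicus, strain Wistar) for inhibition, with a stated time of 60 min (on this read-out higher numbers stand for an effect only at larger amounts of compound and lower numbers for an effect already at smaller amounts), compound 2 gives the lowest number of the three. Compound 1 gives 369000 nM and compound 3 gives 34800 nM; both gaps to compound 2 are beyond the scatter. Among the measured compounds shown here, the one step that has been measured, a 120-fold lower number from compound 1 to compound 2 (2.06 log units; beyond the scatter), shows that placing a nitro group on the shared core moves the read-out by a large amount.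

Compound 4, `CCOc1ccccc1-c1nc2cc(C(F)(F)F)ccc2[nH]1`, has not yet been measured. It differs from compound 2 by ethoxy in place of nitro on an aromatic carbon. For the measured compounds named here, no measured step tells what an ethoxy group does at this place, so the step from compound 2 to compound 4 is not directly anchored. Because the gain on going from compound 1 to compound 2 is tied to the nitro group a 120-fold lower number from compound 1 to compound 2 (2.06 log units; beyond the scatter), removing it is expected to give back part of that gain, landing compound 4 somewhere between compound 1 and compound 2. For compound 4 the expected value is 40000 nM (range 8000 nM to 200000 nM), an estimated step of a 13-fold higher number from compound 2 to compound 4 (1.10 log units; beyond the scatter).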

Compound 4, half-maximal effective concentration: 549000 nM
For compound 4 the middle estimate is 14-fold (1.14 log units) below the measured one; the whole stated range lies below it.
By their numbers in this assay, from the lowest: compound 2; then compound 3; then compounds 1 and 4 (each within the scatter of the next).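

In this assay, the step of a 170-fold higher number from compound 2 to compound 4 (2.24 log units; beyond the scatter) shows that the low number of compound 2 is not kept when ethoxy replaces nitro at this place, on an aromatic carbon ortho to a large group. The step of a 1.5-fold higher number from compound 1 to compound 4 (0.17 log units; within the scatter) puts ethoxy level with plain hydrogen here, so among the compounds shown, filling this place with a group of the same heavy-atom count does not by itself bring the lower number, and only nitro does so. No measurement at hand explains this difference between nitro and ethoxy.

From the compounds shown here alone, whether a nitrile, a carboxylic acid or an amine at this same place would behave like nitro or like ethoxy remains open. So does whether a methoxy group, with its shorter chain, would match ethoxy.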